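The source may hold more compounds than are shown below. What is called first, only, known or untested is meant among the compounds shown, and "the series" means these compounds.

Measured so far:
Compound 1 `COc1ccc(NC(=O)[C@H]2CCCN2C(=O)C2(c3cccc(Cl)c3)CCCC2)nc1` gives 2 nM in an assay on isolated protein for inhibition of histone acetyltransferase p300 (Homo sapiens), with a stated time of 60 min; on this read-out higher numbers stand for weaker inhibition and lower numbers for stronger inhibition.
Compound 2 `O=C(Nc1ccc2[nH]ccc2n1)[C@H]1CCCN1C(=O)C1(c2cccc(Cl)c2)CCCC1` gives 0.159 nM in this assay.

Among the compounds with values here, compound 2 holds the lowest of the two numbers, and its only neighbour is compound 1, which stands far above it. Within the data shown here, the single measured step, a 13-fold lower number from compound 1 to compound 2 (1.10 log units; beyond the scatter), exchanged one ring group on the amide nitrogen for a fused two-ring group.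

Compound 3 `O=C(Nc1ccc2[nH]ncc2n1)[C@H]1CCCN1C(=O)C1(c2cccc(Cl)c2)CCCC1` differs from compound 2 by a group of 9 heavy atoms (6 carbon, 3 nitrogen; one five-membered aromatic ring with 2 hetero atoms, one six-membered aromatic ring with 1 hetero atom) in place of a group of 9 heavy atoms (7 carbon, 2 nitrogen; one five-membered aromatic ring with 1 hetero atom, one six-membered aromatic ring with 1 hetero atom), on an amide-type nitrogen. This is a change of a different kind: the fused two-ring group stays in place, and only one atom within its five-membered ring changes. Among the measured compounds shown here, no measured step directly bears on such a swap, so the large step seen before gives little guidance here. The expected step, a 1.9-fold higher number from compound 2 to compound 3 (0.28 log units; within the scatter), is therefore small and may well lie within the scatter, with a slightly higher number somewhat more likely than a lower one. In this assay compound 3 is estimated at 0.3 nM, within a range of 0.08 nM to 1.2 nM.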

Compound 3, half-maximal inhibitory concentration: 0.159 nM
The estimate for compound 3 lay 1.9-fold (0.28 log units) above the measured number; measured number inside the range.
By their numbers in this assay, from the lowest: compounds 2 and 3 (each within the scatter of the next); then compound 1.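

Adding a second hetero atom to the five-membered ring of the fused group, which raises the hydrogen-bond acceptor count, leaves the number in this assay unmoved, with no change at the digits printed from compound 2 to compound 3 (within the scatter). The large gain over the single-ring group on the amide-type nitrogen therefore does not belong to one fused group alone, since it appears again as a 13-fold lower number from compound 1 to compound 3 (1.10 log units; beyond the scatter), matching the earlier step with the other fused group. Nothing in hand explains why these two fused groups read alike.

The compounds shown do not say whether the hydrogen on the nitrogen of the five-membered ring matters, which a methyl group on that nitrogen would test. They also leave open how the number would respond to an amine or a carboxylic acid on the fused group.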